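This account rests on a few compounds, and the source may have more. Where it says the series, first, only, none or still open, it means among the compounds named here.

Three compounds share one core and differ only in where a bromo sits on the aromatic ring. Compound 1 `O=C1NC(=S)/C(=C/c2ccc(Br)cc2)S1`, compound 2 `O=C1NC(=S)/C(=C/c2cccc(Br)c2)S1` and compound 3 `O=C1NC(=S)/C(=C/c2ccccc2Br)S1` were each tested in a functional assay on HEp-2 cells (Homo sapiens) for cytotoxicity, read by MTT assay, with a stated time of 72 h, tested at 10 ug/mL; on this read-out higher numbers stand for more inhibition of growth at the one concentration tested and lower numbers for less inhibition of growth. In this assay compound 1 gives 18.2%, compound 2 gives 23.6% and compound 3 gives 21.2%. Compound 3 stands second highest of the three numbers; its nearest neighbour is compound 2, higher by an amount within the scatter, and its furthest is compound 1, lower by an amount also within the scatter. The three numbers therefore read as one level rather than as a ranking.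

Compound 4 `O=C1NC(=S)/C(=C/c2ccccc2Cl)S1` differs from compound 3 in one place: chloro in place of bromo on an aromatic carbon. Within the data shown here, no step between measured compounds is at hand to show what such a swap does. The step of a number 0.2 percentage points lower from compound 3 to compound 4 (within the scatter) is therefore expected to be small, no larger than the scatter, in no settled direction. Compound 4 is expected to give 21%, with a range from 10% to 32%.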

Compound 4, percent growth inhibition at one concentration: 21.2%
For compound 4 the middle estimate is 0.2 percentage points below the measured one, within the range that was stated.
By their numbers in this assay, from the lowest: compounds 1, 3, 4 and 2 (each within the scatter of the next).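

In this assay, chloro in place of bromo on an aromatic carbon, ortho to a group of 8 heavy atoms, gives no change at the digits printed from compound 3 to compound 4 (within the scatter). The earlier compounds shown here varied only where the bromo sits, so they could not show what a change of halogen does; here, at this one place, either halogen gives the same reading of growth inhibition. Nothing at hand explains this result.

From the compounds shown here alone, it remains open whether a group other than a halogen at this place, such as an amine, a carboxylic acid or a methoxy group, would give a different number. Going by these compounds, it is also open whether chloro would match bromo where the bromo sits in compound 1 and compound 2, since a single swap at one place says nothing about the others.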